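A few compounds are considered here, and "the series" means these few. Any claim that something is new, unique, unknown or untested is made for them only; others in the source may bear on it.

Among the compounds with values here, in an ADME assay on CEM-SS cells (Homo sapiens) for cytotoxicity, read by XTT assay, with a stated time of 6 days (a higher number here means that more compound is tolerated, a lower number that less compound is tolerated), compound 1 (`CCCC(=O)OCSc1ccccc1C(=O)NCCCCCCC(N)=O`) gives 10.4 uM and compound 2 (`CCCC(=O)OCSc1ccccc1C(=O)Nc1ccccc1C(N)=O`) gives 50.1 uM as the only other number so far. Compound 1 therefore stands lowest of the two, and the gap to compound 2 lies beyond the usual scatter.

The next compound is compound 3 (`CCCC(=O)OCSc1ccccc1C(=O)NCC(=O)OC`), which carries methoxycarbonyl in place of 5-carbamoylpentyl on a saturated chain carbon bound to an amide-type nitrogen. Within the data shown here, no measured pair isolates a change at this place, so the expectation has little support. Compound 1 at 10.4 uM sits at the low end of the numbers seen so far and compound 2 at 50.1 uM is the only higher reference, so a moderate rise in this assay is expected rather than a further fall. The expected step is a 2.9-fold higher number from compound 1 to compound 3 (0.46 log units; beyond the scatter) on this estimate, and the estimated range is wide enough to include no change beyond the scatter. For compound 3 the estimate is 30 uM within an expected range of 10 uM to 100 uM for the measured number.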

Compound 3, half-maximal toxic concentration: 27.3 uM
Beside the measured number, compound 3's estimate is 1.1-fold (0.04 log units) above it; measured number inside the range.
By their numbers in this assay, from the lowest: compound 1; then compounds 3 and 2 (each within the scatter of the next).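

In this assay, within the data shown here, the exchange of 5-carbamoylpentyl for methoxycarbonyl on a saturated chain carbon bound to an amide-type nitrogen gives a 2.6-fold higher number from compound 1 to compound 3 (0.42 log units; beyond the scatter) as a modest step, and this is the first single change whose size can be read at all. The exchange is not a clean one: heavy atoms go from 8 to 4, hydrogen-bond donors from 1 to 0 and hydrogen-bond acceptors from 1 to 2, so this one pair cannot assign the step to chain length, to the loss of the carbamoyl end or to the entry of methoxycarbonyl. No measurement available here bears on why the number moves.

The compounds shown leave open whether the step follows the length of the chain or the identity of its end group, and a longer chain ending in methoxycarbonyl would separate these two readings. Also open, on these data alone, is how far the end group alone matters, which a carboxylic acid or a short chain ending in carbamoyl on the same saturated chain carbon would test.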